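This account rests on a few compounds, and the source may have more. Where it says the series, first, only, none or still open, it means among the compounds named here.

Measured so far:
Compound 1, `COc1cc(-c2nnc(SCC(=O)c3ccc(Br)cc3)n2N)cc(OC)c1OC`: in a functional assay on HCT-116 cells (Homo sapiens) for antiproliferative activity, read by MTT assay, with a stated time of 48 h (a lower number here means a stronger inhibitor, a higher number a weaker inhibitor), compound 1 gives 9230 nM.
Compound 2, `COc1cc(-c2nnc(SCC(=O)c3ccc(C)cc3)n2N)cc(OC)c1OC`: in this assay compound 2 gives 370 nM.
Compound 3, `COc1cc(-c2nnc(SCC(=O)c3ccc(F)cc3)n2N)cc(OC)c1OC`: in this assay compound 3 gives 3230 nM.

Compound 3 holds the second highest of these three numbers: the nearest is compound 1, with a 2.9-fold lower number from compound 1 to compound 3 (0.46 log units; beyond the scatter), and the furthest is compound 2, with an 8.7-fold higher number from compound 2 to compound 3 (0.94 log units; beyond the scatter). Compound 4, `COc1ccc(C(=O)CSc2nnc(-c3cc(OC)c(OC)c(OC)c3)n2N)cc1`, differs from compound 3 by methoxy in place of fluoro on an aromatic carbon. For the measured compounds named here, no measured step brings in a methoxy group, so the evidence is indirect: changes of the group at that place gave a 25-fold lower number from compound 1 to compound 2 (1.40 log units; beyond the scatter) and a 2.9-fold lower number from compound 1 to compound 3 (0.46 log units; beyond the scatter), showing that this group moves the number widely. A lower number is therefore plausible, but its size is uncertain, and a broad range follows. Compound 4 is expected to give 1200 nM (range 300 nM to 5000 nM), which would mean a 2.7-fold lower number from compound 3 to compound 4 (0.43 log units; beyond the scatter).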

Compound 4, half-maximal inhibitory concentration: 1240 nM
Compound 4: the middle estimate sits 1.0-fold (0.01 log units) below what was measured, and the stated range covers the measured number.
By their numbers in this assay, from the lowest: compound 2; then compound 4; then compound 3; then compound 1.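

With methoxy on this aromatic carbon, para to a large group, the number in this assay falls inside the span set by the earlier groups: there is a 2.6-fold lower number from compound 3 to compound 4 (0.42 log units; beyond the scatter) and a 7.4-fold lower number from compound 1 to compound 4 (0.87 log units; beyond the scatter) but also a 3.4-fold higher number from compound 2 to compound 4 (0.53 log units; beyond the scatter) in the opposite direction. Methyl in compound 2 thus keeps the lowest number of the four groups at this place, with every step to it beyond the scatter. Nothing available accounts for this order.

From the compounds shown here alone, whether an amine or a carboxylic acid here would fall below compound 2 remains open. So does whether a longer chain than methoxy would follow compound 4.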